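Moving the pyridine nitrogen in a histamine H2 agonist

This account rests on a few compounds, and the source may have more. Where it says the series, first, only, none or still open, it means among the compounds named here.

compound 1, `N=C(NCCCc1c[nH]cn1)NCCC(c1ccc(F)cc1)c1ccccn1`: 8.01
compound 2, `N=C(NCCCc1c[nH]cn1)NCCC(c1ccccn1)c1ccccn1`: 6.9

Among the measured compounds shown here, in a functional assay on cardiac atrium for agonist activity at histamine H2 receptor (Cavia porcellus) (on this read-out higher numbers stand for higher potency (the scale is a negative logarithm) and lower numbers for lower potency), compound 1 holds the higher of the two numbers; the one step away from it is a number 1.11 log units lower from compound 1 to compound 2 (beyond the scatter). Compound 3, `N=C(NCCCc1c[nH]cn1)NCCC(c1ccc(F)cc1)c1cccnc1`, differs from compound 1 only in that (pyridin-3-yl in place of pyridin-2-yl on a saturated chain carbon bound to an aromatic carbon and a saturated chain carbon). For the measured compounds named here, no measured step changes the place of the ring nitrogen, so the step from compound 1 to compound 3 has no direct precedent, and the large drop seen in a number 1.11 log units lower from compound 1 to compound 2 (beyond the scatter) shows that this part of the molecule matters for this assay. A moderate fall is therefore expected, a number 0.71 log units lower from compound 1 to compound 3 (beyond the scatter), with wide uncertainty. Compound 3 is estimated at 7.3, between 6.5 and 8.1.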

Compound 3, negative logarithm of the half-maximal effective concentration: 8.09
Beside the measured number, compound 3's estimate is 0.79 log units below it, within the range that was stated.
By their numbers in this assay, from the lowest: compound 2; then compounds 1 and 3 (each within the scatter of the next).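

Moving the ring nitrogen gives a number 0.08 log units higher from compound 1 to compound 3 (within the scatter) in this assay so pyridin-2-yl and pyridin-3-yl cannot be told apart at this place. The earlier change, a number 1.11 log units lower from compound 1 to compound 2 (beyond the scatter) and replacing 4-fluorophenyl, therefore marks this carbon as sensitive to some changes but not to this shift of the nitrogen within the ring. Nothing available accounts for this result.

The compounds shown leave open how pyridin-4-yl or unsubstituted phenyl would read at this place. They also leave open whether pyridin-3-yl in place of 4-fluorophenyl would repeat the loss seen with pyridin-2-yl.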